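Cycloheptyl in place of cyclopentyl on the urea nitrogen

The source may report more compounds than this note shows. Statements on the series, on what has been measured and on what is new or still open speak of the compounds shown alone.

Two compounds share a urea core and an aryl-methyl arm on the same nitrogen. Compound 1 `Cc1cc(C)c(NC(=O)N(Cc2cccc(-c3nnn(C)n3)c2)C2CCCCCC2)c(C)c1` carries a cycloheptyl group and a methyltetrazolyl substituent on the arm; in an assay on microsomes from intestine for inhibition of acyl-CoA:cholesterol acyltransferase (Oryctolagus cuniculus) (a lower number here means a stronger inhibitor, a higher number a weaker inhibitor), compound 1 gives 100 nM. Compound 2 `Cc1cc(C)c(NC(=O)N(Cc2cccc(-c3cc[nH]n3)c2)C2CCCC2)c(C)c1` carries a cyclopentyl group and a pyrazolyl substituent; in this assay compound 2 gives 22 nM. Compound 2 stands at the lower of the two numbers, and its distance to compound 1 lies beyond the scatter. Since compound 1 and compound 2 differ in two places, nothing can be said about either change on its own.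

Compound 3 `Cc1cc(C)c(NC(=O)N(Cc2cccc(-c3cc[nH]n3)c2)C2CCCCCC2)c(C)c1` keeps the pyrazolyl arm of compound 2 and differs from it in one place: cycloheptyl in place of cyclopentyl on an amide-type nitrogen. Going by the values given here, no step that isolates this change has been measured. The account expects no step beyond the scatter in this assay, with a wide range because the effect of the ring size is not resolved by the two measured compounds. For compound 3 the estimate in this assay is 25 nM, within 8 nM to 80 nM, which means an expected step of a 1.1-fold higher number from compound 2 to compound 3 (0.06 log units; within the scatter).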

Compound 3, half-maximal inhibitory concentration: 65 nM
Compound 3: the middle estimate sits 2.6-fold (0.41 log units) below what was measured; low and high end bracket the measured number.
By their numbers in this assay, from the lowest: compound 2; then compounds 3 and 1 (each within the scatter of the next).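

With the pyrazolyl arm held fixed, cycloheptyl in place of cyclopentyl on the amide-type nitrogen gives in this assay a 3.0-fold higher number from compound 2 to compound 3 (0.47 log units; beyond the scatter). This step isolates what the earlier pair, differing in two places, could not: at this position, the change of ring alone moves the number beyond the scatter, towards a weaker inhibitor. With cycloheptyl held fixed, 1H-pyrazol-3-yl in place of 2-methyl-2H-tetrazol-5-yl on an aromatic carbon gives a 1.5-fold lower number from compound 1 to compound 3 (0.19 log units; within the scatter) and cannot be told apart from no effect, so the two arm groups are not distinguished on this cycloheptyl background. Nothing at hand bears on the reason for either step.

The compounds shown leave open how the number behaves for a cyclohexyl ring, which would show whether it follows ring size in a steady way, and for an open chain such as n-pentyl on the same nitrogen. They also leave open whether the two arm groups would remain indistinguishable with cyclopentyl on that nitrogen, and how an arm carrying a carboxylic acid or an amine in place of either ring would read.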